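This account rests on a few compounds, and the source may have more. Where it says the series, first, only, none or still open, it means among the compounds named here.

Compounds measured so far in a functional assay on DU-145 cells (Homo sapiens) for cytotoxicity, read by MTT assay; on this read-out lower numbers stand for stronger inhibition and higher numbers for weaker inhibition:
Compound 1, `CCCC(O)CC(=O)O[C@H](CC=C(C)C)C1=CC(=O)c2c(O)ccc(O)c2C1=O`, gives in this assay > 100000 nM, which is a limit of the assay and not a number.
Compound 2, `COCCO[C@H](CC=C(C)C)C1=CC(=O)c2c(O)ccc(O)c2C1=O`, gives in this assay 43200 nM.
Compound 3, `CC(C)=CC[C@@H](OCC(C)O)C1=CC(=O)c2c(O)ccc(O)c2C1=O`, gives in this assay 16100 nM.

Compound 3 holds the lowest of the two numbers recorded in this assay. Compound 2 stands nearest, with a 2.7-fold lower number from compound 2 to compound 3 (0.43 log units; beyond the scatter). The remaining value, that of compound 1, is the limit of > 100000 nM in this assay, at which 1 of the 3 values shown sits.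

The next compound is compound 4, `CC(C)=CC[C@@H](OC(=O)c1ccoc1)C1=CC(=O)c2c(O)ccc(O)c2C1=O`. Its difference from compound 3: (furan-3-yl)carbonyl in place of 2-hydroxypropyl on an oxygen on a saturated carbon. The group that enters carries a carbonyl on the oxygen on the saturated carbon, as does the group on compound 1, whereas compounds 2 and 3 carry ethers there. Within the data shown here, the steps that bear on this are an at least 6.2-fold lower number from compound 1 to compound 3 (0.79 log units; beyond the scatter) and an at least 2.3-fold lower number from compound 1 to compound 2 (0.36 log units; beyond the scatter), both running from the carbonyl-bearing group to an ether and both beyond the scatter; the present change runs the other way. A higher number is therefore expected for compound 4 in this assay, and the chance that only a limit is reported is real.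

Compound 4 is expected at 60000 nM, within a range of 20000 nM to 200000 nM. The expected step is a 3.7-fold higher number from compound 3 to compound 4 (0.57 log units; beyond the scatter).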

Compound 4, half-maximal inhibitory concentration: > 100000 nM
Compound 4 ended at the assay's limit; the forecaster's own chance of this, stated with the estimate: 35%; middle value at least 1.6-fold (0.22 log units) away from the limit.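

In this assay, replacing either ether on the oxygen on a saturated carbon with (furan-3-yl)carbonyl moves the compound to the assay's limit, giving an at least 6.2-fold higher number from compound 3 to compound 4 (0.79 log units; beyond the scatter) and an at least 2.3-fold higher number from compound 2 to compound 4 (0.36 log units; beyond the scatter), both beyond the scatter and both open-ended on the high side. Compound 1 and compound 4, the two compounds with a carbonyl on this oxygen, each end at a limit and not a number, so the step between them cannot be read: the limit of > 100000 nM in this assay, at which 2 of the 4 values shown sit. Among these four compounds, numbers below the limit occur only with the two ethers, 2-methoxyethyl and 2-hydroxypropyl, and no compound goes against this split, while furan-3-yl on the carbonyl carbon yields no readable number, as with the 2-hydroxypentyl of compound 1.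

The compounds shown do not separate the contribution of the carbonyl from that of the furan ring, as compound 4 differs from both ethers in the whole group and no furan-3-ylmethyl ether is among them. Also open, as far as these compounds go, is how an amine or a carboxylic acid at the end of a longer ether chain would read in this assay.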